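Hydrogen in place of bromo in compound 1

A few compounds are considered here, and "the series" means these few. Any claim that something is new, unique, unknown or untested is made for them only; others in the source may bear on it.

compound 1 `CC(NC(=O)NS(=O)(=O)c1ccc(Cl)cc1)c1cc(Br)ccc1OCc1ccccc1` gives 57500 nM
compound 2 `COc1ccc(OC)c(CNC(=O)NS(=O)(=O)c2ccc(Cl)cc2)c1` gives > 300000 nM (a limit)
compound 3 `COc1ccc(Cl)cc1C(C)NC(=O)NS(=O)(=O)c1ccc(Cl)cc1` gives > 300000 nM (a limit)

For the measured compounds named here, in a functional assay on thoracic aorta (Rattus norvegicus, strain Wistar), with a stated time of 15 min (on this read-out lower numbers stand for an effect already at smaller amounts and higher numbers for an effect only at larger amounts of compound), compound 1 gives 57500 nM, the only true number among the measured compounds. For compound 2 and compound 3 there is no number, only (the limit of > 300000 nM in this assay, at which 2 of the 3 values shown sit).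

Compound 4 `CC(NC(=O)NS(=O)(=O)c1ccc(Cl)cc1)c1ccccc1OCc1ccccc1` is compound 1 with a single change: hydrogen in place of bromo on an aromatic carbon. Hydrogen replaces bromo on an aromatic carbon, meta to a large group and para to a benzyloxy group. Going by the values given here, no two measured compounds differ in just one place, so no measured step shows what this swap does. With only compound 1 at 57500 nM as a numerical anchor, a modest move toward larger amounts is expected in this assay, and it may not clear the scatter by much. The expected change is a 2.3-fold higher number from compound 1 to compound 4 (0.35 log units; beyond the scatter). For compound 4 the estimated value is 130000 nM, with an expected range of 45000 nM to 300000 nM.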

Compound 4, half-maximal effective concentration: 157000 nM
For compound 4 the middle estimate is 1.2-fold (0.08 log units) below the measured one, within the range that was stated.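

For the compounds shown here, this is the first comparison here that changes only one place on the shared core: in this assay, hydrogen in place of bromo, para to a benzyloxy group, gives a 2.7-fold higher number from compound 1 to compound 4 (0.44 log units; beyond the scatter). The position therefore affects the read-out, and compound 1, which carries the bromo, acts at smaller amounts, although the step is modest. Compound 4 still gives a true number rather than a limit, so removing the bromo does not by itself push the value out of the measurable range.

A single swap cannot show whether bromo is special at this position or whether another group there, such as a nitrile or an amine, would give a lower or higher number. Compound 2 and compound 3 differ from these compounds in more than one place, so no steps to them can be read, and each has only a limit as its value: the limit of > 300000 nM in this assay, at which 2 of the 4 values shown sit.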